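The source may report more compounds than this note shows. Statements on the series, on what has been measured and on what is new or still open speak of the compounds shown alone.

Working notes on a flavone amide series.

Compound 1 `COc1ccccc1C(=O)Nc1cccc(-c2oc3cc(-c4ccc(F)cc4)ccc3c(=O)c2O)c1` is the reference point. In a functional assay on GTL 16 cells for antiproliferative activity against GTL 16 cell line (Homo sapiens), read by CCK-8 assay, with a stated time of 72 h (a lower number here means a stronger inhibitor, a higher number a weaker inhibitor), compound 1 gives 6370 nM. Compound 2 `Cc1ccccc1C(=O)Nc1cccc(-c2oc3cc(-c4ccc(F)cc4)ccc3c(=O)c2O)c1` differs from compound 1 by methyl in place of methoxy on an aromatic carbon, and compound 2 gives 24800 nM in this assay; the step is a 3.9-fold higher number from compound 1 to compound 2 (0.59 log units; beyond the scatter). Compound 3 `COc1cccc(C(=O)Nc2cccc(-c3oc4cc(-c5ccc(F)cc5)ccc4c(=O)c3O)c2)c1` carries the same atoms as compound 1 joined differently, the difference being (3-methoxyphenyl in place of 2-methoxyphenyl on a carbonyl carbon). Compound 3 gives 12500 nM, and the step of a 2.0-fold higher number from compound 1 to compound 3 (0.29 log units; within the scatter) is within the scatter, as is a 2.0-fold lower number from compound 2 to compound 3 (0.30 log units; within the scatter).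

Compound 4 `Cc1cccc(C(=O)Nc2cccc(-c3oc4cc(-c5ccc(F)cc5)ccc4c(=O)c3O)c2)c1` is not yet measured. It differs from compound 3 by methyl in place of methoxy on an aromatic carbon. This is the same kind of change as that from compound 1 to compound 2, occurring twice among the four compounds, but not the same: in compound 1 to compound 2 the place is ortho to a large group, whereas in compound 3 to compound 4 it is meta to a large group. Within the data shown here, the only measured instance of methyl in place of methoxy on an aromatic carbon is a 3.9-fold higher number from compound 1 to compound 2 (0.59 log units; beyond the scatter), a modest weakening. Whether the meta placement reproduces that is not known from these data, so the expectation for compound 4 is anchored on the earlier step with widened bounds. Compound 4 is estimated at 35000 nM in this assay, between 14000 nM and 90000 nM. The expected step of a 2.8-fold higher number from compound 3 to compound 4 (0.45 log units; beyond the scatter) rests on compound 3 at 12500 nM and on the step of a 3.9-fold higher number from compound 1 to compound 2 (0.59 log units; beyond the scatter).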

Compound 4, half-maximal inhibitory concentration: 10900 nM
Beside the measured number, compound 4's estimate is 3.2-fold (0.51 log units) above it, outside the stated range (below it).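

The replacement of methoxy by methyl does not carry over as a fixed step between the two cores in this assay: the same change on two cores in this assay, a 3.9-fold higher number (0.59 log units; beyond the scatter) from compound 1 to compound 2 and a 1.1-fold lower number (0.06 log units; within the scatter) from compound 3 to compound 4, 4.5-fold (0.65 log units) apart, beyond the scatter of two such steps

Going from 3-methoxyphenyl to 3-methylphenyl, the step is a 1.1-fold lower number from compound 3 to compound 4 (0.06 log units; within the scatter), so the modest weakening seen with the 2-methoxyphenyl amide cannot be assumed for this pair. Moving the methyl from the 2-methylphenyl amide to the 3-methylphenyl amide gives a 2.3-fold lower number from compound 2 to compound 4 (0.36 log units; beyond the scatter), a modest step, while a 1.7-fold higher number from compound 1 to compound 4 (0.23 log units; within the scatter) stays within the scatter. Among these compounds, each case rests on a single pair, so the result shows only that the step differs between these two pairs; it gives no general rule for where the group sits on the phenyl ring, and it does not say why the two steps differ.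

Still open, on these data alone, is whether a chlorine, an amine or a carboxylic acid in the place of the methoxy or methyl would track either pair of compounds. Also open, as far as these compounds go, is whether the difference between the two steps would persist with another group in place of the fluorine on the shared core.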